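This account rests on a few compounds, and the source may have more. Where it says the series, first, only, none or still open, it means among the compounds named here.

Measured compounds in a functional assay on NCI/ADR-RES cells (Homo sapiens) for cytotoxicity, read by sulforhodamine B assay, with a stated time of 48 h; on this read-out higher numbers stand for weaker inhibition of growth and lower numbers for stronger inhibition of growth:
compound 1, `ClCc1ccccc1Cn1cnc2c(Cl)nc(Cl)nc21` — 1510 nM
compound 2, `ClCc1ccc(Cn2cnc3c(Cl)nc(Cl)nc32)cc1` — 16600 nM
compound 3, `ClCc1cccc(Cn2cnc3nc(Cl)nc(Cl)c32)c1` — 1540 nM

Compound 1 has the lowest number of the three. Compound 3 sits so close that the two cannot be told apart within the usual scatter, while compound 2 gives a higher number that lies beyond it. Compound 4, `Nc1nc(Cl)c2ncn(Cc3ccccc3CCl)c2n1`, differs from compound 1 in one place: amino in place of chloro on an aromatic carbon. Among the compounds with values here, no measured pair shows this same exchange, so the size of its effect is unknown here. The expectation for this assay is a modest step upward, a 1.7-fold higher number from compound 1 to compound 4 (0.22 log units; within the scatter), meaning a somewhat weaker inhibition of growth. Compound 4 is therefore estimated at 2500 nM, within a range from 800 nM to 8000 nM.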

Compound 4, concentration for 50% growth inhibition: 4470 nM
Compound 4: middle estimate off by 1.8-fold (0.25 log units), on the low side, within the range that was stated.
By their numbers in this assay, from the lowest: compounds 1 and 3 (each within the scatter of the next); then compound 4; then compound 2.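

In this assay, amino in place of chloro on this aromatic carbon, between two ring nitrogen atoms, gives a 3.0-fold higher number from compound 1 to compound 4 (0.47 log units; beyond the scatter) and so a modest loss of growth inhibition beyond the scatter. The exchange therefore shows that the group at this position affects the read-out, although compound 4 still has a measurable value with amino there.

From the compounds shown here alone, whether methylamino or methoxy on this carbon would fall nearer compound 1 or compound 4 stays open, as does the effect of the same exchange at the remaining chloro group. Nothing shown bears on why the number rises.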